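From an Ether Acid to an Ethenyl Ester

A few compounds are considered here, and "the series" means these few. Any claim that something is new, unique, unknown or untested is made for them only; others in the source may bear on it.

Compound 1, `O=C(COc1ccncc1-c1ccc2ccccc2c1)N1CCOCC1`, gives 9%.
Compound 2, `O=C(O)COc1ccncc1-c1ccc2ccccc2c1`, gives 16%.
Compound 3, `CN1CCN(C(=O)/C=C/c2ccncc2-c2ccc(F)cc2)CC1`, gives 84%.

These numbers come from an assay on a protein complex for inhibition of CDK8/Cyclin C (Homo sapiens), with a stated time of 1 h, tested at 10 uM; a higher number here means more inhibition at the concentration tested (going by the name of the read-out), a lower number less inhibition. Among the three, compound 2 stands second highest; its nearest neighbour is compound 1, and the step of a number 7 percentage points higher from compound 1 to compound 2 (within the scatter) lies within the usual scatter, while compound 3 sits far above it, beyond the scatter. The next compound, compound 4, `COC(=O)/C=C/c1ccncc1-c1ccc2ccccc2c1`, differs from compound 2 in one place: 2-(methoxycarbonyl)ethenyl in place of carboxymethoxy on an aromatic carbon. Among the measured compounds shown here, no measured step bears directly on this exchange. For the measured compounds named here, the only measured step, a number 7 percentage points higher from compound 1 to compound 2 (within the scatter), concerns a different part of the molecule and is small. Compound 3 gives a high number, but it differs from compound 4 in more than one place, so it offers only a loose hint. A rise beyond the scatter is therefore expected, though with wide uncertainty, and the step of a number 19 percentage points higher from compound 2 to compound 4 (beyond the scatter) is the estimate. Compound 4 is thus expected to give 35%, between 10% and 65%.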

Compound 4, a percentage reported as inhibition, at one concentration (the size of the read-out at that concentration, not a potency): 102%
The estimate for compound 4 lay 67 percentage points below the measured number, and the stated range ends below it.
By their numbers in this assay, from the lowest: compounds 1 and 2 (each within the scatter of the next); then compound 3; then compound 4.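

In this assay, the exchange at this aromatic carbon, opposite the ring nitrogen, gives a number 86 percentage points higher from compound 2 to compound 4 (beyond the scatter). That is a far larger move than the earlier change on the carbonyl carbon, a number 7 percentage points higher from compound 1 to compound 2 (within the scatter), so this position on the shared core clearly responds to what is attached there. The exchange replaces the whole carboxymethoxy group at once, and no measurement at hand explains the rise.

Going by these compounds, it remains open whether the ethenyl link, the methyl ester or the two together account for the step. A carboxylic acid on the same ethenyl chain, or a saturated chain carrying the methyl ester, would help separate these parts, and an amine at this position would show how far the response extends beyond esters.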